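Bulkier Alkyl on the Saturated Ring: Solubility Outlook

This account rests on a few compounds, and the source may have more. Where it says the series, first, only, none or still open, it means among the compounds named here.

Measured compounds:
compound 1, `O=C1/C(=C/c2cccc(C(F)(F)F)c2)CC(c2ccccc2)C/C1=C\c1cccc(C(F)(F)F)c1`, 1100 nM
compound 2, `CC1C/C(=C\c2cccc(C(F)(F)F)c2)C(=O)/C(=C/c2cccc(C(F)(F)F)c2)C1`, < 1000 nM

In a physicochemical assay for solubility, in phosphate buffer, at pH 7.4 (on this read-out lower numbers stand for lower solubility and higher numbers for higher solubility), compound 1 gives 1100 nM. For compound 2 only a limit of this assay is reported, < 1000 nM, which is not a number but the floor of what the method can resolve (the limit of < 1000 nM in this assay, at which 1 of the 2 values shown sits). From the compounds shown here alone, compound 2 therefore stands at or beneath that floor, and its exact place on the scale is unknown.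

The next compound, compound 3, `CC(C)(C)C1C/C(=C\c2cccc(C(F)(F)F)c2)C(=O)/C(=C/c2cccc(C(F)(F)F)c2)C1`, differs from compound 2 in one place: tert-butyl in place of methyl on a saturated ring carbon.

Among the compounds with values here, only one measured step exists for comparison, an at least 1.1-fold lower number from compound 1 to compound 2 (0.04 log units; that floor lies within the scatter), and it exchanged phenyl for methyl at that same saturated ring carbon. No measured step concerns tert-butyl, so nothing shown bears directly on this change. Since compound 2 already sits at the limit, the step to compound 3 is expected to leave it at or beneath that limit, with a step that the limit leaves unreadable from compound 2 to compound 3 as the expected shift. Compound 3 is expected to give about 500 nM, within a range from 100 nM to 1500 nM, and most likely reported only as a limit.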

Compound 3, solubility: < 1000 nM
Compound 3 gave a limit, no number; the forecaster's own chance of this, stated with the estimate: 70%; the middle value is on the limit's open side.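

In this assay, compound 3 gives a limit and not a number, just as compound 2 does, so the step from methyl to tert-butyl on a saturated ring carbon cannot be read in either size or direction. The new information comes from the pair that can be compared, where tert-butyl in place of phenyl at this carbon gives an at least 1.1-fold lower number from compound 1 to compound 3 (0.04 log units; that floor lies within the scatter), which is only a floor on the step and does not separate the two compounds. This position has now carried phenyl, methyl and tert-butyl, and the two compounds with methyl and tert-butyl report the same limit: the limit of < 1000 nM in this assay, at which 2 of the 3 values shown sit.

From the compounds shown here alone, how far compound 2 and compound 3 actually lie beyond that limit stays open, and with it how methyl and tert-butyl rank against each other. Going by these compounds, how an amine or a carboxylic acid on this saturated ring carbon would read in this assay also stays open, since a value that can be read there would be needed to give such a comparison a size.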